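The source may hold more compounds than are shown below. What is called first, only, known or untested is meant among the compounds shown, and "the series" means these compounds.

Working notes on the series, read in a functional assay on MCF7 cells (Homo sapiens) for antiproliferative activity, read by MTT assay, with a stated time of 72 h; a lower number here means a stronger inhibitor, a higher number a weaker inhibitor. Compound 1 (`CC1=CC[C@H]2[C@H](CC[C@]2(C)O)C(C)(C)[C@@H]1CC[C@H]1[C@]2(C)CC[C@H](OC(=O)NS(=O)(=O)c3ccc(C)cc3)C(C)(C)O[C@H]2CC[C@@]1(C)O`) gives > 50000 nM, which is a limit of the assay and not a number. Going by the values given here, compound 2 (`COc1ccc(C(=O)O[C@H]2CC[C@]3(C)[C@H](CC[C@@](C)(O)[C@H]3CC[C@@H]3C(C)=CC[C@H]4[C@H](CC[C@]4(C)O)C3(C)C)OC2(C)C)cc1`) gives 41700 nM, the only true number so far. The next compound, compound 3 (`CC1=CC[C@H]2[C@H](CC[C@]2(C)O)C(C)(C)[C@@H]1CC[C@H]1[C@]2(C)CC[C@H](OC(=O)c3ccccc3Cl)C(C)(C)O[C@H]2CC[C@@]1(C)O`), keeps the shared core and carries 2-chlorophenyl in place of 4-methoxyphenyl on a carbonyl carbon.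

Among the compounds with values here, one measured step bears on this change, at the same place: 4-methoxyphenyl in place of ((4-methylphenyl)sulfonyl)amino, which is an at least 1.1-fold lower number from compound 1 to compound 2 (0.07 log units; that floor lies within the scatter). Within the data shown here, no measured step yet replaces one aryl group with another, so this step gives only a loose guide. On that basis, no change beyond the scatter is expected in this assay, and no direction can be assigned. Compound 3 could also return only a limit, as with the limit of > 50000 nM in this assay, at which 1 of the 2 values shown sits.

For compound 3 the estimated value is 38000 nM, with an expected range of 17000 nM to 50000 nM. The estimated step is a 1.1-fold lower number from compound 2 to compound 3 (0.04 log units; within the scatter).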

Compound 3, half-maximal inhibitory concentration: 12100 nM
Estimate against measurement, compound 3: 3.1-fold (0.50 log units) above; the whole stated range lies above it.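

In this assay, going by these compounds alone, the change from 4-methoxyphenyl to 2-chlorophenyl on a carbonyl carbon gives a 3.4-fold lower number from compound 2 to compound 3 (0.54 log units; beyond the scatter), the first evidence that replacing one aryl group with another at this position can shift the read-out beyond the scatter. 2-Chlorophenyl in place of ((4-methylphenyl)sulfonyl)amino gives an at least 4.1-fold lower number from compound 1 to compound 3 (0.61 log units; beyond the scatter), also beyond the scatter, whereas the floor for 4-methoxyphenyl at the same place, an at least 1.1-fold lower number from compound 1 to compound 2 (0.07 log units; that floor lies within the scatter), lies within it. The value of compound 1 is a limit of the assay and not a number, so both steps from it are floors only: the limit of > 50000 nM in this assay, at which 1 of the 3 values shown sits.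

The compounds shown do not separate the contribution of the incoming chlorine from that of the departing methoxy group, and unsubstituted phenyl and 4-chlorophenyl would be the direct comparisons. Also open, on these data alone, is whether an aryl group is needed on this carbonyl carbon at all, a question that a simple alkyl chain or an aminoalkyl group there would address, and whether any such change can improve on compound 3, which gives 12100 nM.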